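The compounds below may be only part of what the source reports. "The series", "measured", "known", "first", "only" and "open" are said of these compounds alone.

Measured compounds in an in vitro functional assay on CHO-CREluc cells for antagonist activity at growth hormone secretagogue receptor type 1 (Homo sapiens), read by a luciferase reporter, with a stated time of 4 h; on this read-out lower numbers stand for stronger inhibition and higher numbers for weaker inhibition:
compound 1 `CCN1CCN(CC(=O)NC2(c3ccc(Cl)c(Cl)c3)C(=O)Nc3cc(Cl)cc(Cl)c32)CC1=O`: 2780 nM
compound 2 `Cc1cc2c(cc1Cl)NC(=O)C2(NC(=O)CN1CCN(C)CC1)c1cccc(Cl)c1`: 1180 nM

Compound 1 gives 2780 nM in this assay, the higher of the two numbers. Compound 2 gives 1180 nM, and the gap between the two lies beyond the usual scatter, so compound 2 is the stronger inhibitor of the pair. Compound 3 `CN1CCCN(CC(=O)NC2(c3ccc(Cl)c(Cl)c3)C(=O)Nc3cc(Cl)cc(Cl)c32)CC1` has not been measured. It is derived from compound 1 by one change: 4-methyl-1,4-diazepan-1-yl in place of 4-ethyl-3-oxopiperazin-1-yl on a saturated chain carbon bound to a carbonyl carbon. For the measured compounds named here, no two measured compounds differ in only one place, so no measured step shows how this change acts on the shared core. Compound 2 does give the lower number 1180 nM, but it differs from compound 1 in several places at once, so it offers only a loose hint. For compound 3 the expected value is 1600 nM, with a range from 600 nM to 5000 nM. The step expected is a 1.7-fold lower number from compound 1 to compound 3 (0.24 log units; within the scatter), a modest move toward stronger inhibition that may not clear the scatter.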

Compound 3, half-maximal inhibitory concentration: 64 nM
Compound 3: the middle estimate sits 25-fold (1.40 log units) above what was measured; measured number outside the range, below it.
By their numbers in this assay, from the lowest: compound 3; then compound 2; then compound 1.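

In this assay, putting 4-methyl-1,4-diazepan-1-yl in place of 4-ethyl-3-oxopiperazin-1-yl on a saturated chain carbon bound to a carbonyl carbon gives a 43-fold lower number from compound 1 to compound 3 (1.64 log units; beyond the scatter), a large step beyond the scatter. For the compounds shown here, this is the first comparison with the rest of the structure held constant, and it shows that the group at this place can by itself shift the read-out strongly toward stronger inhibition. Nothing available explains why this swap has so large an effect.

Going by these compounds, the swap changes several features at once: a six-membered ring becomes a seven-membered ring, the ring carbonyl disappears, and ethyl gives way to methyl, so which of these matters remains open. A 4-ethyl-1,4-diazepan-1-yl group at this place would help to separate the ring from the small group it carries.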